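A few compounds are considered here, and "the series" means these few. Any claim that something is new, unique, unknown or untested is made for them only; others in the source may bear on it.

Compound 1 `C[C@@H](NC(=O)c1ccc(C#Cc2ccccc2)cn1)C(C)(C)O` reaches 43.2% in an ADME assay on HEK293 cells for agonist activity at metabotropic glutamate receptor 5 (Rattus norvegicus), read by fluorescence and calcium flux (a higher number here means a larger maximal response, a lower number a smaller maximal response), while compound 2 `C[C@@H](NC(=O)c1ccc(C#Cc2ccccc2F)cn1)C(C)(C)O` reaches 29.6%, the lower of the two numbers. For the measured compounds named here, the only measured step, a number 13.6 percentage points lower from compound 1 to compound 2 (beyond the scatter), shows that placing a fluoro on the aromatic ring lowered the response. Compound 3 `C[C@@H](NC(=O)c1ccc(C#Cc2ccc(F)cc2)cn1)C(C)(C)O` keeps that fluorine but moves it: 4-fluorophenyl in place of 2-fluorophenyl on a triple-bonded carbon. Going by the values given here, no measured step covers such a shift, so the step from compound 2 to compound 3 is expected to be small, probably within the scatter, perhaps a number 3.4 percentage points higher from compound 2 to compound 3 (within the scatter). Compound 3 is therefore expected to give about 33%, estimated to fall between 18% and 48%.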

Compound 3, largest response reached (reported as efficacy), in percent of the reference or control that the assay uses: 38.4%
Compound 3: middle estimate off by 5.4 percentage points, on the low side, within the range that was stated.
By their numbers in this assay, from the lowest: compounds 2, 3 and 1 (each within the scatter of the next, the first and the last beyond it).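

Moving the fluorine around the ring gives a number 8.8 percentage points higher from compound 2 to compound 3 (within the scatter) in this assay, so 2-fluorophenyl and 4-fluorophenyl cannot be told apart here. Even so, adding fluorine as 4-fluorophenyl gives a number 4.8 percentage points lower from compound 1 to compound 3 (within the scatter), so the clear loss seen with 2-fluorophenyl does not extend to both fluorinated compounds. No measured evidence accounts for this pattern. The compounds shown leave open how a different group on this ring, such as chlorine, methyl or methoxy, would change the maximal response, and whether the 4-fluorophenyl result would hold for them.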